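Swapping Hydroxy for Amino on a Semicarbazone Series

The source may report more compounds than this note shows. Statements on the series, on what has been measured and on what is new or still open speak of the compounds shown alone.

Measured compounds:
- compound 1, `CN(C)c1ccc(/C=N/NC(=O)Nc2ccc(Br)cc2)cc1`, 300 mg/kg
- compound 2, `C/C(=N\NC(=O)Nc1ccc(Br)cc1)c1ccccc1`, 100 mg/kg
- compound 3, `C/C(=N\NC(=O)Nc1ccc(Br)cc1)c1ccc(O)cc1`, 300 mg/kg

In a functional assay on the whole organism with Mus musculus as the target, in the maximal electroshock model, with a stated time of 0.5 h (a lower number here means that less compound is needed, a higher number that more compound is needed for the effect), compound 3 gives 300 mg/kg, level with compound 1 at the digits shown and together with it the highest of the three numbers; compound 2 needs the lowest dose, and the one step measured, a 3.0-fold higher number from compound 2 to compound 3 (0.48 log units; beyond the scatter), lies beyond the scatter.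

Compound 4, `C/C(=N\NC(=O)Nc1ccc(Br)cc1)c1ccc(N)cc1`, has not yet been tested. It differs from compound 3 in one place: amino in place of hydroxy on an aromatic carbon. Among the measured compounds shown here, the only step that bears on this position is a 3.0-fold higher number from compound 2 to compound 3 (0.48 log units; beyond the scatter), a modest rise when hydroxy entered. For the measured compounds named here, no measured pair shows what amino does in place of hydroxy, so the data give no direction for this swap. The expectation is therefore no step beyond the scatter, no change at the digits printed from compound 3 to compound 4 (within the scatter). Compound 4 is estimated at 300 mg/kg, with a range from 100 mg/kg to 600 mg/kg.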

Compound 4, minimum effective dose: 300 mg/kg
Estimate against measurement, compound 4: no gap at the digits printed; the measured number falls inside the stated range.
By their numbers in this assay, from the lowest: compound 2; then compounds 1, 3 and 4 (each within the scatter of the next).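

In this assay the change from 4-hydroxyphenyl to 4-aminophenyl gives no change at the digits printed from compound 3 to compound 4 (within the scatter) and so, at this position, amino and hydroxy cannot be told apart by dose. Set against the compound with hydrogen at this place, amino gives a 3.0-fold higher number from compound 2 to compound 4 (0.48 log units; beyond the scatter) and thus matches the rise seen with hydroxy, which shows that this rise is not confined to a single group. Nothing measured here explains why the two groups match.

As far as these compounds go, whether any group on this aromatic carbon would raise the dose, or only these two, stays open. A methoxy group, a fluorine or a carboxylic acid at the same place would help to settle that.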